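The source may hold more compounds than are shown below. What is called first, only, known or untested is meant among the compounds shown, and "the series" means these compounds.

Measured compounds:
Compound 1 `C=CCn1c(=O)/c(=C\c2cccc(F)c2)[nH]c(=O)/c1=C\c1ccccc1OC`: 19700 nM
Compound 2 `C=CCn1c(=O)/c(=C\c2ccccc2F)[nH]c(=O)/c1=C\c1ccccc1OC`: "not active" (no number reported)
Compound 3 `C=CCn1c(=O)/c(=C\c2ccc(C)cc2)[nH]c(=O)/c1=C\c1ccccc1OC`: "not active" (no number reported)

In a functional assay on A549 cells (Homo sapiens) for cytotoxicity, read by CCK-8 assay, with a stated time of 72 h (on this read-out higher numbers stand for weaker inhibition and lower numbers for stronger inhibition), compound 1 gives 19700 nM. Compound 2 gives "not active" (no number reported) and compound 3 gives "not active" (no number reported); for these two no number was reported, so compound 3 cannot be placed against the others on this read-out beyond saying that it did not reach a measurable value. Compound 4 `C=CCn1c(=O)/c(=C\c2cccc(Cl)c2Cl)[nH]c(=O)/c1=C\c1ccccc1OC` has not yet been measured. It differs from compound 3 by 2,3-dichlorophenyl in place of 4-methylphenyl on a double-bonded chain carbon bound to an aromatic carbon. For the measured compounds named here, no measured step covers this change, and only one of the three measured compounds returned a number at all, itself a weak one. Compound 4 is therefore expected to be weak in this assay, and may again return no number. Compound 4 is estimated at 25000 nM, with a range of 8000 nM to 80000 nM.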

Compound 4, half-maximal inhibitory concentration: 2300 nM
Beside the measured number, compound 4's estimate is 11-fold (1.04 log units) above it; measured number outside the range, below it.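

In this assay, the group on this double-bonded chain carbon bound to an aromatic carbon clearly affects the read-out: 2,3-dichlorophenyl in place of 3-fluorophenyl gives an 8.6-fold lower number from compound 1 to compound 4 (0.93 log units; beyond the scatter). Compound 3 carries 4-methylphenyl at the same position. Compound 3 returned no number. No measurement shown explains why the dichlorinated compound gives the lower number. Still open, as far as these compounds go, is whether one chlorine alone would give a similar result, and how an amine or a carboxylic acid on this phenyl ring would behave.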